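Aryl urea exchange in a diaryl ether series

This account rests on a few compounds, and the source may have more. Where it says the series, first, only, none or still open, it means among the compounds named here.

Measured compounds in a functional assay on MDA-MB-231 cells (Homo sapiens) for antiproliferative activity, read by MTT assay, with a stated time of 72 h; on this read-out higher numbers stand for weaker inhibition and lower numbers for stronger inhibition:
compound 1, `Cn1cnnc1-c1cc(Oc2ccc(NC(=O)Nc3cccc(C(F)(F)F)c3)cc2F)ccn1`: 6470 nM
compound 2, `CN(C)CCn1cnnc1-c1cc(Oc2ccc(NC(=O)Nc3cccc(C(F)(F)F)c3)cc2F)ccn1`: 16400 nM
compound 3, `CN(C)CCn1cnnc1-c1cc(Oc2ccc(NC(=O)Nc3ccccc3C(F)(F)F)cc2F)ccn1`: > 50000 nM

Compound 1 stands at the strong end of this small set. The step of a 2.5-fold higher number from compound 1 to compound 2 (0.40 log units; beyond the scatter) moves compound 2 to a weaker place. Going by the values given here, compound 3 gives only a limit of this assay, > 50000 nM, so no number is known for it; it is the one value sitting at the limit of > 50000 nM in this assay, at which 1 of the 3 values shown sits, and compound 3 therefore stands at the weak end of everything measured.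

Compound 4, `CN(C)CCn1cnnc1-c1cc(Oc2ccc(NC(=O)Nc3ccc(F)c(Cl)c3)cc2F)ccn1`, differs from compound 3 by 3-chloro-4-fluorophenyl in place of 2-(trifluoromethyl)phenyl on an amide-type nitrogen. Among the compounds with values here, the one measured step that touches this site is an at least 3.0-fold higher number from compound 2 to compound 3 (0.48 log units; beyond the scatter), where replacing 3-(trifluoromethyl)phenyl by 2-(trifluoromethyl)phenyl lost activity. Compound 4 carries a 3-chloro-4-fluorophenyl, a ring substituted as named in compound 2 rather than in compound 3, so that step is expected to be largely undone. Compound 4 is therefore expected to show an at least 3.3-fold lower number from compound 3 to compound 4 (0.52 log units; beyond the scatter), toward stronger inhibition, landing near compound 2. The estimate for compound 4 in this assay is 15000 nM, with an expected range from 5000 nM to 50000 nM.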

Compound 4, half-maximal inhibitory concentration: 8320 nM
Compound 4: the middle estimate sits 1.8-fold (0.26 log units) above what was measured; the measured number falls inside the stated range.
By their numbers in this assay, from the lowest: compounds 1, 4 and 2 (each within the scatter of the next, the first and the last beyond it). At a limit, above all of these: compound 3.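

At the amide-type nitrogen, 3-chloro-4-fluorophenyl in place of 2-(trifluoromethyl)phenyl gives, in this assay, an at least 6.0-fold lower number from compound 3 to compound 4 (0.77 log units; beyond the scatter), so the weakness of compound 3 does not extend to every exchange of this aryl group. Set against 3-(trifluoromethyl)phenyl, the same group gives a 2.0-fold lower number from compound 2 to compound 4 (0.29 log units; within the scatter), so these two aryl groups are not told apart in this assay, and a trifluoromethyl group is not required on this ring to reach the level of compound 2. The first of these steps is only a bound, since compound 3 is read at a limit: the limit of > 50000 nM in this assay, at which 1 of the 4 values shown sits.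

As far as these compounds go, whether a ring carrying chlorine alone or fluorine alone would hold this level remains open. So does whether a morpholine in place of the dimethylamino group, or the methyl of compound 1, would change the result with 3-chloro-4-fluorophenyl in place.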